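A Methyl on the Hydroxyethyl Chain of Compound 3

This account rests on a few compounds, and the source may have more. Where it says the series, first, only, none or still open, it means among the compounds named here.

Measured in an ADME assay on THP-1 cells (Homo sapiens) for cytotoxicity, read by flow cytometry and propidium iodide staining, with a stated time of 72 h (on this read-out lower numbers stand for stronger inhibition and higher numbers for weaker inhibition), compound 3 (`Cc1nc(CS(=O)(=O)c2ccc(F)cc2)c([N+](=O)[O-])n1CCO`) gives > 728000 nM as a limit of the assay and not a number. Compound 1 (`Cc1nc(CS(=O)(=O)c2ccccc2)c([N+](=O)[O-])n1CCO`) gives > 768000 nM as a limit too. Compound 2 (`Cc1nc(CS(=O)(=O)c2ccc(Br)cc2)c([N+](=O)[O-])n1CCO`) gives an actual number, 124000 nM in this assay as well.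

Compound 4 (`Cc1nc(CS(=O)(=O)c2ccc(F)cc2)c([N+](=O)[O-])n1CC(C)O`) keeps the fluoro group of compound 3 and turns 2-hydroxyethyl into 2-hydroxypropyl (methyl in place of hydrogen on a saturated chain carbon bound to an oxygen on a saturated carbon and a saturated chain carbon). Every measured step lies on an aromatic carbon and none on this chain, so they bear on the change only indirectly. Bromo in place of hydrogen gave an at least 6.1-fold lower number from compound 1 to compound 2 (0.79 log units; beyond the scatter) and fluoro in place of bromo gave an at least 5.8-fold higher number from compound 2 to compound 3 (0.76 log units; beyond the scatter) in the same read-out of this assay here. Fluoro in place of hydrogen gave a step that the two limits leave unreadable from compound 1 to compound 3 and so adds little.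

The expectation therefore rests on compound 3, whose limit of > 728000 nM is the nearest guide. No change beyond the scatter is expected, and the expected step is an at least 1.0-fold lower number from compound 3 to compound 4 (0.01 log units; that floor lies within the scatter) at most a small one. Compound 4 is estimated at 700000 nM with an expected range of 250000 nM to 1100000 nM and may again prove to be only a limit.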

Compound 4, half-maximal inhibitory concentration: > 699000 nM
Compound 4: only a limit was reported (the forecaster's own chance of this, stated with the estimate: 70%); the middle value lies beyond the limit too.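

Going by these compounds alone, compound 3 and compound 4 both stand in this assay as limits of the assay and not as numbers, so no step between them can be read. The compounds shown leave open whether 2-hydroxypropyl in place of 2-hydroxyethyl changes the number at all, on these compounds or on one with an actual value, such as compound 2.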